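Two Chlorines on a Phenyl Ring Replace a Chloropyridine

The source may hold more compounds than are shown below. What is called first, only, known or untested is meant among the compounds shown, and "the series" means these compounds.

Three sulfonamides have been tested in an ADME assay on HCT-116 cells (Homo sapiens) for cytotoxicity, read by CellTiter-Glo, with a stated time of 72 h; a lower number here means a stronger inhibitor, a higher number a weaker inhibitor. Compound 1 `COc1ccccc1-c1cccc(S(=O)(=O)N2CCC(N3CCC(C)CC3)CC2)c1` gives > 5000 nM, which is a limit of the measurement rather than a number. Compound 3 `Cc1cc(C)c(S(=O)(=O)N2CCC(N3CCC(O)CC3)CC2)c(C)c1` likewise gives only the limit > 5000 nM. Compound 2 `CC1CCN(C2CCN(S(=O)(=O)c3cccnc3Cl)CC2)CC1` stands at > 10000 nM, again a limit and not a measured number. Of the three values shown, two sit at the limit of > 5000 nM in this assay, at which 2 of the 3 values shown sit, and one at the limit of > 10000 nM in this assay, at which 1 of the 3 values shown sits, so no step between measured compounds can be drawn and no cause for any difference can be named.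

Compound 4 `CC1CCN(C2CCN(S(=O)(=O)c3ccc(Cl)c(Cl)c3)CC2)CC1` has not yet been measured. It differs from compound 2 in one place: 3,4-dichlorophenyl in place of 2-chloropyridin-3-yl on a sulfonyl sulfur. Compound 2 shows only the limit > 10000 nM, and with every measured value resting at a limit, no step beyond the scatter is expected in this assay in either direction from this change. The expected outcome is that compound 4 again sits at a limit, so the step that the limit leaves unreadable from compound 2 to compound 4 is estimated as none of note. Compound 4 is therefore estimated at 15000 nM, with a range from 5000 nM to 50000 nM.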

Compound 4, half-maximal inhibitory concentration: > 5000 nM
Compound 4 ended at the assay's limit; the forecaster's own chance of this, stated with the estimate: 85%; the middle value does not contradict the limit.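

In this assay, compound 2 and compound 4 both rest at limits rather than measured numbers, so no step can be read between them. The compounds shown leave open whether any group on the sulfonyl sulfur would give a readable number.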